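Swapping the Aryl Group on a Lactone Inhibitor

A few compounds are considered here, and "the series" means these few. Any claim that something is new, unique, unknown or untested is made for them only; others in the source may bear on it.

Three compounds share one core and differ only in the group attached to one aromatic carbon. Compound 1 `O=C1C[C@H](O)C[C@@H](/C=C/c2c(Cl)cc(Cl)cc2-c2ccccc2)O1` carries a phenyl there, and in an assay for inhibition of 3-hydroxy-3-methylglutaryl-coenzyme A reductase (Rattus norvegicus) (a higher number here means a weaker inhibitor, a lower number a stronger inhibitor), compound 1 gives 80 nM. Compound 2 `COc1ccc(-c2cc(Cl)cc(Cl)c2/C=C/[C@@H]2C[C@@H](O)CC(=O)O2)cc1` carries a 4-methoxyphenyl, and compound 2 gives 470 nM, which is a 5.9-fold higher number from compound 1 to compound 2 (0.77 log units; beyond the scatter). Compound 3 `O=C1C[C@H](O)C[C@@H](/C=C/c2c(Cl)cc(Cl)cc2-c2ccc(Cl)c(Cl)c2)O1` carries a 3,4-dichlorophenyl, and compound 3 gives 25 nM, the lowest number of the three; this is a 3.2-fold lower number from compound 1 to compound 3 (0.51 log units; beyond the scatter) and a 19-fold lower number from compound 2 to compound 3 (1.27 log units; beyond the scatter). Compound 4 `Cc1cccc(-c2cc(Cl)cc(Cl)c2/C=C/[C@@H]2C[C@@H](O)CC(=O)O2)c1` is the next step: 3-methylphenyl in place of 3,4-dichlorophenyl on an aromatic carbon. Both earlier steps at this aromatic carbon bear on it: putting 3,4-dichlorophenyl in place of phenyl lowered the number modestly, while methoxy in place of hydrogen raised it. A 3-methylphenyl is neither of these, so the expectation is a modest rise, an estimated 2.4-fold higher number from compound 3 to compound 4 (0.38 log units; beyond the scatter). Compound 4 is therefore expected to give about 60 nM, within a range from 20 nM to 180 nM.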

Compound 4, half-maximal inhibitory concentration: 16 nM
The estimate for compound 4 lay 3.8-fold (0.57 log units) above the measured number; measured number outside the range, below it.
By their numbers in this assay, from the lowest: compounds 4 and 3 (each within the scatter of the next); then compound 1; then compound 2.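

Replacing the 3,4-dichlorophenyl with a 3-methylphenyl leaves the number in this assay unresolved from where it was (a 1.6-fold lower number from compound 3 to compound 4 (0.19 log units; within the scatter)), so at this aromatic carbon a ring carrying one methyl and no chlorine matches the dichlorinated ring within the scatter. Adding that one methyl to the plain phenyl gives the first gain seen from so small a change (a 5.0-fold lower number from compound 1 to compound 4 (0.70 log units; beyond the scatter)), whereas the 4-methoxyphenyl sits far behind the 3-methylphenyl (a 29-fold lower number from compound 2 to compound 4 (1.47 log units; beyond the scatter)), so a single small group on this ring can move the number strongly in either direction. Nothing measured here explains why these groups differ.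

The compounds shown leave open whether a 4-methylphenyl, a 3-methoxyphenyl or a 3-chlorophenyl would give a similar number. Going by these compounds, it also remains open how a ring carrying an amine or a carboxylic acid would behave at this position.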